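Replacing the side group of compound 1

The source may hold more compounds than are shown below. What is called first, only, known or untested is meant among the compounds shown, and "the series" means these compounds.

In an ADME assay on HEp-2 cells (Homo sapiens) for cytotoxicity (on this read-out higher numbers stand for lower toxicity in this test and lower numbers for higher toxicity in this test), compound 1 (`CC(C)CCn1c(Cn2c(=O)n(C(C)C)c3ccccc32)nc2cc(CNS(C)(=O)=O)ccc21`) gives 30800 nM. This lies within the scatter of compound 3 (`CC(C)CCn1c(Cn2c(=O)n(C(C)C)c3ccccc32)nc2ccc(C(N)=O)cc21`) at 49900 nM, while compound 2 (`CC(C)CCn1c(Cn2c(=O)n(C(C)C)c3ccccc32)nc2ccc(C#N)cc21`) sits clearly lower at 10000 nM.

The next entry is compound 4 (`CC(C)CCn1c(Cn2c(=O)n(C(C)C)c3ccccc32)nc2cc(-c3ncon3)ccc21`), reached by one exchange: 1,2,4-oxadiazol-3-yl in place of (methanesulfonamido)methyl on an aromatic carbon. In words, 1,2,4-oxadiazol-3-yl takes the place of (methanesulfonamido)methyl on an aromatic carbon.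

Among the compounds with values here, only one measured step is available: a 5.0-fold higher number from compound 2 to compound 3 (0.70 log units; beyond the scatter), with carbamoyl in place of cyano on an aromatic carbon. It is a modest step and a different exchange, so it bears only indirectly. It shows that a single group change on the shared core can move this number beyond the scatter, though not by much. Within the data shown here, no measured compound carries the entering group.

Like the entering group, the nitrile of compound 2 is neither a carbamoyl nor a sulfonamide, and compound 2 gives 10000 nM. That gives a weak lean towards a lower number, from one compound only. The expected change is a 1.7-fold lower number from compound 1 to compound 4 (0.23 log units; within the scatter), an estimated step that would stay within the scatter. For compound 4 the estimate is 18000 nM, with an expected range of 6000 nM to 50000 nM.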

Compound 4, half-maximal cytotoxic concentration: 223000 nM
Compound 4: middle estimate off by 12-fold (1.09 log units), on the low side; the measured number lies above the stated range.
By their numbers in this assay, from the lowest: compound 2; then compounds 1 and 3 (each within the scatter of the next); then compound 4.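

In this assay, within the data shown here, the exchange gives a 7.2-fold higher number from compound 1 to compound 4 (0.86 log units; beyond the scatter) and is the first measured step at this aromatic carbon, which is meta to a fused ring and para to a fused ring. On the core of compound 1, the methanesulfonamide chain and its hydrogen-bond donor can therefore be replaced by an aromatic five-membered ring with no donor without the number falling, and here it rises beyond the scatter. The exchange alters the ring count, the donor count and the acceptor count together, so this single step does not assign the rise to any one of these differences, and no supporting measurement offers an explanation for it.

Open, going by these compounds, is whether the rise belongs to 1,2,4-oxadiazol-3-yl itself or would also follow from another group at this carbon, such as a carboxylic acid, an aminomethyl group or a plain phenyl ring. On these data alone, with compound 4 at 223000 nM, it is also open whether 1,2,4-oxadiazol-5-yl or a methyl group on the 1,2,4-oxadiazole ring would stay within the scatter of that number.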